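Anilide variation on the shared core: compound 4

A few compounds are considered here, and "the series" means these few. Any claim that something is new, unique, unknown or untested is made for them only; others in the source may bear on it.

Measured so far in a functional assay on NCI-H1975 cells (Homo sapiens) for inhibition, read by MTT assay, with a stated time of 72 h; a higher number here means a weaker inhibitor, a lower number a stronger inhibitor:
compound 1 `O=C(CSc1nc(Nc2ccccc2)c2ccccc2n1)Nc1cccc(Br)c1`: 10100 nM
compound 2 `CCc1cccc(NC(=O)CSc2nc(Nc3ccccc3)c3ccccc3n2)c1`: 12000 nM
compound 3 `O=C(CSc1nc(Nc2ccccc2)c2ccccc2n1)Nc1ccc(F)cc1`: 16500 nM

All three numbers lie within the scatter of one another; compound 1 gives the lowest of them, with a 1.2-fold higher number from compound 1 to compound 2 (0.07 log units; within the scatter) and a 1.6-fold higher number from compound 1 to compound 3 (0.21 log units; within the scatter), and a 1.4-fold higher number from compound 2 to compound 3 (0.14 log units; within the scatter). Compound 4 `O=C(CSc1nc(Nc2ccccc2)c2ccccc2n1)Nc1ccc(C(F)(F)F)cc1` is not yet measured and differs from compound 1 by 4-(trifluoromethyl)phenyl in place of 3-bromophenyl on an amide-type nitrogen. Going by the values given here, the steps that bear on this change are the two earlier exchanges of the aryl group on the amide-type nitrogen, a 1.6-fold higher number from compound 1 to compound 3 (0.21 log units; within the scatter) and a 1.4-fold higher number from compound 2 to compound 3 (0.14 log units; within the scatter), both within the scatter. Hence no step beyond the scatter is expected for compound 4: a 1.4-fold higher number from compound 1 to compound 4 (0.14 log units; within the scatter). Compound 4 is therefore estimated at 14000 nM, with a range from 6000 nM to 35000 nM.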

Compound 4, half-maximal inhibitory concentration: 11700 nM
Estimate against measurement, compound 4: 1.2-fold (0.08 log units) above; measured number inside the range.
By their numbers in this assay, from the lowest: compounds 1, 4, 2 and 3 (each within the scatter of the next).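

In this assay, the aryl group on the amide-type nitrogen also accepts 4-(trifluoromethyl)phenyl, with 10 heavy atoms against 7 for 3-bromophenyl, and the steps stay within the scatter (a 1.2-fold higher number from compound 1 to compound 4 (0.06 log units; within the scatter); a 1.0-fold lower number from compound 2 to compound 4 (0.01 log units; within the scatter)). Exchanging the fluoro group for a trifluoromethyl group likewise gives no step beyond the scatter (a 1.4-fold lower number from compound 3 to compound 4 (0.15 log units; within the scatter)). No measured property is available to account for this result.

On these data alone, whether an amine, a carboxylic acid or a longer chain on this aryl ring would move the number beyond the scatter remains open. So does the effect of changes elsewhere on the shared core.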